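This account rests on a few compounds, and the source may have more. Where it says the series, first, only, none or still open, it means among the compounds named here.

Working notes on the series. Compound 1 `Nc1ncnc(Oc2ccc(NC(=O)C3(C(=O)Nc4ccc(F)cc4)CC3)cc2F)c1/C=N/OCCO` gives 2.37 in a physicochemical assay for lipophilicity, using the shake flask method (on this read-out higher numbers stand for higher lipophilicity and lower numbers for lower lipophilicity), and stands lowest of the three measured compounds. Compound 3 `CNc1ncnc(Oc2ccc(NC(=O)C3(C(=O)Nc4ccc(F)cc4)CC3)cc2F)c1/C=N/OC` is nearest to it with 3.52 in this assay; compound 2 `CC(C)(C)OC(=O)N/N=C/c1c(N)ncnc1Oc1ccc(NC(=O)C2(C(=O)Nc3ccc(F)cc3)CC2)cc1F` is furthest with 3.7 in this assay. Both gaps lie beyond the scatter. Going by the values given here, the only single-point step among the measured compounds is a number 1.33 log units higher from compound 1 to compound 2 (beyond the scatter), which shows how strongly a change at the oxygen-bound chain on the double-bonded nitrogen can move this assay. Compound 3 differs from compound 1 in two places at once, so it is read only for its value.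

The next compound, compound 4 `Nc1ncnc(Oc2ccc(NC(=O)C3(C(=O)Nc4ccc(F)cc4)CC3)cc2F)c1/C=N/OCC(=O)N1CCOCC1`, differs from compound 1 as follows: (morpholin-4-yl)carbonyl in place of hydroxymethyl on a saturated chain carbon bound to an oxygen. Among the compounds with values here, no measured step matches this change; the step from compound 1 to compound 2 bears on it only in that it sits on the same chain, and it was large. The change here trades a hydrogen-bond donor for a group with two acceptors and a non-aromatic ring, so a smaller move is expected, in either direction, possibly not beyond the scatter. For compound 4 the estimate in this assay is 2.6, between 1.9 and 3.3, meaning an expected step of a number 0.23 log units higher from compound 1 to compound 4 (within the scatter).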

Compound 4, partition coefficient: 2.1
Compound 4: middle estimate off by 0.50 log units, on the high side; measured number inside the range.
By their numbers in this assay, from the lowest: compounds 4 and 1 (each within the scatter of the next); then compounds 3 and 2 (each within the scatter of the next).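

In this assay, (morpholin-4-yl)carbonyl in place of hydroxymethyl on a saturated chain carbon bound to an oxygen gives a number 0.27 log units lower from compound 1 to compound 4 (within the scatter) and so stays inside the usual scatter, even though the entering group carries a six-membered non-aromatic ring and no hydrogen-bond donor. On the double-bonded nitrogen, ((morpholin-4-yl)carbonyl)methoxy in place of (tert-butoxycarbonyl)amino gives a number 1.60 log units lower from compound 2 to compound 4 (beyond the scatter) as a large step, so among these three compounds both 2-hydroxyethoxy and ((morpholin-4-yl)carbonyl)methoxy stand well apart from (tert-butoxycarbonyl)amino while remaining within the scatter of each other. No measurement is available that would account for either step.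

Still open, on these data alone, is whether a basic amine such as a dimethylamino group, or a carboxylic acid, on the same saturated chain carbon would also remain within the scatter of compound 1. Equally open, as far as these compounds go, is whether a longer chain ending in hydroxyl or in the morpholine amide would hold that level, or would instead move towards the number of compound 2.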